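Dimethyl substitution on the pyrrole of compound 3

The compounds below may be only part of what the source reports. "The series", "measured", "known", "first", "only" and "open" are said of these compounds alone.

Measured so far:
Compound 1 `Cc1cccc(C)c1-c1cccc(COc2ccc3c(c2)OCC3CC(=O)O)c1`: 74.4%
Compound 2 `O=C(O)CC1COc2cc(OCc3cccc(N4CCCCC4)c3)ccc21`: 50.3%
Compound 3 `O=C(O)CC1COc2cc(OCc3cccc(-n4cccc4)c3)ccc21`: 41.9%

All values come from a functional assay on CHO cells for agonist activity at Free fatty acid receptor 1 (Homo sapiens), read by FLIPR and calcium flux, with a stated time of 90 s, tested at 300 nM; a lower number here means a weaker effect, a higher number a stronger effect of the compound at the concentration tested. Compound 3 gives the lowest of the three numbers; its gap to compound 2 is within the scatter, its gap to compound 1 is beyond it. Compound 4 `Cc1ccc(C)n1-c1cccc(COc2ccc3c(c2)OCC3CC(=O)O)c1` differs from compound 3 as follows: 2,5-dimethyl-1H-pyrrol-1-yl in place of 1H-pyrrol-1-yl on an aromatic carbon.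

The step that bears on this change is a number 32.5 percentage points lower from compound 1 to compound 3 (beyond the scatter), since 2,6-dimethylphenyl and 2,5-dimethyl-1H-pyrrol-1-yl both carry methyl groups where 1H-pyrrol-1-yl carries none. The steps of a number 24.1 percentage points lower from compound 1 to compound 2 (beyond the scatter) and a number 8.4 percentage points lower from compound 2 to compound 3 (within the scatter) add little on this point. An increase beyond the scatter is therefore expected, though not necessarily all the way to compound 1.

For compound 4 the expected value is 60%, range 42% to 78%.
The expected step is a number 18.1 percentage points higher from compound 3 to compound 4 (beyond the scatter).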

Compound 4, a percentage reported as activity, at one concentration (the size of the read-out at that concentration, not a potency): 71.3%
Compound 4: the middle estimate sits 11.3 percentage points below what was measured, within the range that was stated.
By their numbers in this assay, from the lowest: compounds 3 and 2 (each within the scatter of the next); then compounds 4 and 1 (each within the scatter of the next).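

Putting 2,5-dimethyl-1H-pyrrol-1-yl in place of 1H-pyrrol-1-yl gives a number 29.4 percentage points higher from compound 3 to compound 4 (beyond the scatter), and in place of piperidin-1-yl gives a number 21 percentage points higher from compound 2 to compound 4 (beyond the scatter), so the methyl-bearing pyrrole separates from both groups without methyl groups. In place of 2,6-dimethylphenyl it gives a number 3.1 percentage points lower from compound 1 to compound 4 (within the scatter), so at this position a dimethyl-substituted five-membered aromatic ring and the dimethylphenyl group cannot be told apart in this read-out. Nothing available explains these steps.

As far as these compounds go, it remains open whether a single methyl on the pyrrole is enough, and whether ethyl or chloro in place of the two methyl groups would hold the number.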